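From compound 3 to compound 4: losing the side chain

The source may hold more compounds than are shown below. What is called first, only, known or untested is meant among the compounds shown, and "the series" means these compounds.

The series is followed in a functional assay on the whole organism for inhibition, with Rattus norvegicus as the target; on this read-out higher numbers stand for an effect only at larger amounts of compound and lower numbers for an effect already at smaller amounts. Compound 1 `Fc1ccc(-n2cc(C3=CCNCC3)c3cc(Cl)ccc32)cc1` gives 1.5 umol/kg. Compound 2 `CN1CCN(CCN2CCC(c3cn(-c4ccc(F)cc4)c4ccc(Cl)cc34)CC2)C1=O`, which carries a chain on the amine nitrogen in a ring, gives 0.021 umol/kg, a much lower number than that of compound 1.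

Compound 3 `O=C1NCCN1CCN1CC=C(c2cn(-c3ccc(F)cc3)c3ccc(C(F)(F)F)cc23)CC1` is reported as > 0.66 umol/kg, and this is a limit of the assay, not a number. As far as these compounds go, its true position on the scale therefore stays open.

Compound 4 `Fc1ccc(-n2cc(C3=CCNCC3)c3cc(C(F)(F)F)ccc32)cc1` follows from compound 3 by one structural change: hydrogen in place of 2-(2-oxoimidazolidin-1-yl)ethyl on an amine nitrogen in a ring. In words, hydrogen stands in place of 2-(2-oxoimidazolidin-1-yl)ethyl on an amine nitrogen in a ring. Within the data shown here, no measured pair isolates this change, so any expectation rests on a single comparison. Like compound 4, compound 1 has hydrogen on that nitrogen, and compound 1 gives 1.5 umol/kg. Compound 4 is therefore expected to need a dose of similar size in this assay.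

The expected change is a step that the limit leaves unreadable from compound 3 to compound 4, a move towards larger amounts of compound, though its size is uncertain without a number for the starting point. For compound 4 the estimated value is 2 umol/kg, with an expected range from 0.6 umol/kg to 7 umol/kg.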

Compound 4, dose for half-maximal effect: > 0.86 umol/kg
Compound 4 gave a limit, no number (the forecaster's own chance of this, stated with the estimate: 20%); the middle value does not contradict the limit.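

In this assay compound 4 gives > 0.86 umol/kg, which is a limit of the assay and not a number. Among these compounds, no step from compound 3 or from compound 1 to compound 4 can therefore be read. The compounds shown leave open how hydrogen in place of 2-(2-oxoimidazolidin-1-yl)ethyl, or trifluoromethyl in place of chloro, changes the dose.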